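This account rests on a few compounds, and the source may have more. Where it says the series, first, only, none or still open, it means among the compounds named here.

Measured compounds:

compound 1 `C[C@H](/N=C(\S)Nc1ccccn1)c1cccc2ccccc12` — > 100000 nM in a functional assay on RBL-2H3 cells (Rattus norvegicus) for inhibition (a higher number here means a weaker inhibitor, a lower number a stronger inhibitor), a limit of the assay
compound 2 `C[C@H](/N=C(\S)Nc1nccs1)c1cccc2ccccc12` — > 100000 nM in this assay, a limit of the assay
compound 3 `C[C@@H](/N=C(\S)Nc1ccccn1)c1cccc2ccccc12` — > 100000 nM, a limit of the assay

Compound 1 and compound 3 share their atoms and bonds and differ only in the configuration as drawn (the two compounds have the same atoms and bonds and differ only in configuration as drawn: 1 of 2 stereo elements differ; a stereocentre at a saturated chain carbon is drawn S in compound 1 and R in compound 3). The step that the two limits leave unreadable from compound 1 to compound 3 cannot be read, because the limit of > 100000 nM in this assay, at which 3 of the 3 values shown sit, and because of the fact that compounds 1 and 3 differ only in the configuration as drawn.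

The change from compound 1 to compound 2 is 1,3-thiazol-2-yl in place of pyridin-2-yl on an amine nitrogen. The step that the two limits leave unreadable from compound 1 to compound 2 is likewise not readable, because of the limit of > 100000 nM in this assay, at which 3 of the 3 values shown sit.

Compound 4 `C[C@@H](/N=C(\S)Nc1nccs1)c1cccc2ccccc12` is not yet measured in this assay. The change from compound 3 to compound 4 is 1,3-thiazol-2-yl in place of pyridin-2-yl on an amine nitrogen, the same change, at the same place, as that from compound 1 to compound 2. Nothing among the three measured compounds gives a readable step, so no size can be carried over; what is known is that every value sits at the limit.

Compound 4 is therefore expected to give 100000 nM, most likely reported again as a limit, with the expected step of a number no higher from compound 3 to compound 4 (the limit leaves the size open) resting on the limit shown by compound 3, > 100000 nM, and on the unreadable step that the two limits leave unreadable from compound 1 to compound 2.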

Compound 4, half-maximal inhibitory concentration: > 100000 nM
Compound 4 ended at the assay's limit (the forecaster's own chance of this, stated with the estimate: 85%); the middle value lies on the limit itself.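

Neither the step from compound 3 to compound 4 nor the step from compound 2 to compound 4 can be read, because both ends of each step sit at an assay limit: the limit of > 100000 nM in this assay, at which 4 of the 4 values shown sit.

The compounds shown leave open whether swapping pyridin-2-yl for 1,3-thiazol-2-yl, or changing the configuration as drawn, alters inhibition in this assay at all.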